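A side chain exchanged on a shared core

A few compounds are considered here, and "the series" means these few. Any claim that something is new, unique, unknown or untested is made for them only; others in the source may bear on it.

In a functional assay on HeLa cells (Homo sapiens) for cytotoxicity, read by MTT assay (on this read-out higher numbers stand for weaker inhibition and lower numbers for stronger inhibition), compound 1 (`CCCCC(CC(=O)O[C@H](CC=C(C)C)C1=CC(=O)c2c(O)ccc(O)c2C1=O)OC(C)=O`) gives 73500 nM and compound 2 (`CC(C)=CC[C@@H](OC(=O)CC(O)c1ccccc1)C1=CC(=O)c2c(O)ccc(O)c2C1=O`) gives 44500 nM on the same read-out. Compound 3 (`CC(=O)OC(C)CO[C@H](CC=C(C)C)C1=CC(=O)c2c(O)ccc(O)c2C1=O`) gives 40100 nM and so lies within the usual scatter of both. Compound 4 (`CC[C@@](C)(O)CC(=O)O[C@H](CC=C(C)C)C1=CC(=O)c2c(O)ccc(O)c2C1=O`) carries (2-hydroxy-2-methylbutyl)carbonyl in place of 2-acetoxypropyl on an oxygen on a saturated carbon. For the measured compounds named here, the one measured step that bears on this change is a 1.7-fold lower number from compound 1 to compound 2 (0.22 log units; within the scatter) and it stays within the scatter, although it too exchanges a group carrying acetoxy for one carrying hydroxy. The three measured compounds differ widely in their side chains, yet their numbers all lie within the scatter of each other. No step beyond the scatter is therefore expected in this assay here. The expected step is a 1.1-fold higher number from compound 3 to compound 4 (0.05 log units; within the scatter) and it would lie within the scatter. For compound 4 the estimated value is 45000 nM with an expected range from 20000 nM to 90000 nM in repeated measurements.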

Compound 4, half-maximal inhibitory concentration: 17900 nM
Compound 4: middle estimate off by 2.5-fold (0.40 log units), on the high side; the measured number lies below the stated range.
By their numbers in this assay, from the lowest: compound 4; then compounds 3, 2 and 1 (each within the scatter of the next).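

In this assay, for the compounds shown here, the side chain on this oxygen now shows an effect on the number: a 2.2-fold lower number from compound 3 to compound 4 (0.35 log units; beyond the scatter) stands beyond the scatter, which no step among the earlier compounds did. Compound 2 also carries a hydroxy on its chain, yet a 2.5-fold lower number from compound 2 to compound 4 (0.40 log units; beyond the scatter) is beyond the scatter too, so a hydroxy alone does not set compound 4 apart, and a 4.1-fold lower number from compound 1 to compound 4 (0.61 log units; beyond the scatter) is the largest step shown here. Nothing given here accounts for these steps.

Going by these compounds, it remains open whether an amine or a carboxylic acid in place of that hydroxy, or a longer chain in place of the ethyl part of the 1-hydroxy-1-methylpropyl group, would move the number further. The compounds shown also do not tell whether the defined stereocentre of the entering group bears on the result.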